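Piperidinyl for cyclohexyl on the sulfonyl sulfur, two cores

The source may hold more compounds than are shown below. What is called first, only, known or untested is meant among the compounds shown, and "the series" means these compounds.

Measured so far:
compound 1 `O=S(=O)(C1CCCCC1)N1CCc2nc(C#Cc3ccccc3)sc2C1`: 480 nM
compound 3 `O=S(=O)(N1CCCCC1)N1CCc2nc(C#Cc3ccccc3)sc2C1`: 780 nM
compound 2 `O=S(=O)(C1CCCCC1)N1Cc2nc(C#Cc3ccccc3)sc2C1`: limit > 10000 nM

In an assay on HEK293 cells for negative allosteric modulation of metabotropic glutamate receptor 5 (Homo sapiens), read by FLIPR, with a stated time of 1 h (a lower number here means a stronger inhibitor, a higher number a weaker inhibitor), compound 1 gives 480 nM and compound 3 gives 780 nM. The change between them is piperidin-1-yl in place of cyclohexyl on a sulfonyl sulfur and it made a 1.6-fold higher number from compound 1 to compound 3 (0.21 log units; within the scatter). Compound 2 reaches only a limit of this assay, > 10000 nM. That limit is the limit of > 10000 nM in this assay, at which 1 of the 3 values shown sits. The difference between the core of compound 1 and the core of compound 2 is not broken down here.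

Compound 4 `O=S(=O)(N1CCCCC1)N1Cc2nc(C#Cc3ccccc3)sc2C1` is not yet measured. It differs from compound 2 by piperidin-1-yl in place of cyclohexyl on a sulfonyl sulfur, the same change at the same place. The step expected in this assay is a step that the limit leaves unreadable from compound 2 to compound 4, resting on the small measured step of a 1.6-fold higher number from compound 1 to compound 3 (0.21 log units; within the scatter), which stayed within the scatter. Compound 4 is therefore estimated at 20000 nM, with a range from 8000 nM to 60000 nM, and most likely this assay will again give only a limit.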

Compound 4, half-maximal inhibitory concentration: > 10000 nM
Compound 4: a limit, no number; the forecaster's own chance of this, stated with the estimate: 85%; the middle value is on the limit's open side.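

Compound 2 and compound 4 both give only a limit in this assay, and no step can be read between them: the limit of > 10000 nM in this assay, at which 2 of the 4 values shown sit.

As far as these compounds go, how piperidin-1-yl in place of cyclohexyl acts on the core of compound 2 stays open.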